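A few compounds are considered here, and "the series" means these few. Any claim that something is new, unique, unknown or untested is made for them only; others in the source may bear on it.

Measured so far in a functional assay on A549 cells (Homo sapiens) for antiproliferative activity, read by sulforhodamine B assay, with a stated time of 48 h; on this read-out higher numbers stand for weaker inhibition and lower numbers for stronger inhibition:
- compound 1 `COc1cc(C(=O)/C=C\Nc2ccc(-c3nc4cc(OC)c(OC)c(OC)c4s3)cc2C)cc([N+](=O)[O-])c1OC`: 17400 nM
- compound 2 `COc1ccc(C(=O)/C=C\Nc2ccc(-c3nc4cc(OC)c(OC)c(OC)c4s3)cc2)cc1[N+](=O)[O-]`: 21200 nM

Compound 2 at 21200 nM has the higher of the two numbers, but compound 1 at 17400 nM lies within the scatter of it, so the two values cannot be told apart. The next compound to read is compound 3 `COc1cc(C(=O)/C=C\Nc2ccc(-c3nc4cc(OC)c(OC)c(OC)c4s3)cc2)cc([N+](=O)[O-])c1OC`, reached from compound 2 by methoxy in place of hydrogen on an aromatic carbon. Among the compounds with values here, no measured step shows what such a change does. The expectation therefore rests only on the two close values, and no step beyond the scatter is expected in this assay, in either direction. The expected change is a 1.2-fold lower number from compound 2 to compound 3 (0.10 log units; within the scatter). For compound 3 the estimated value is 17000 nM, with an expected range of 7000 nM to 40000 nM.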

Compound 3, half-maximal inhibitory concentration: 11800 nM
Compound 3: middle estimate off by 1.4-fold (0.16 log units), on the high side, within the range that was stated.
By their numbers in this assay, from the lowest: compounds 3, 1 and 2 (each within the scatter of the next).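

In this assay, within the data shown here, methoxy in place of hydrogen on the aromatic carbon ortho to a methoxy group and meta to a nitro group gives a 1.8-fold lower number from compound 2 to compound 3 (0.25 log units; within the scatter), the first measured step at this position, and this step does not leave the scatter. Hydrogen in place of methyl on an aromatic carbon gives a 1.5-fold lower number from compound 1 to compound 3 (0.17 log units; within the scatter), so this second single change also stays within the scatter, and the methyl of compound 1 has no readable effect here. No available measurement accounts for either step.

From the compounds shown here alone, whether an amine or a longer alkoxy chain at the methoxy position would move the number beyond the scatter remains open. Also open, going by these compounds, is what a carboxylic acid in place of the nitro group would do in this assay.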